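From Thiophene to Furan on the Saturated Ring Carbon

The compounds below may be only part of what the source reports. "The series", "measured", "known", "first", "only" and "open" are said of these compounds alone.

Compound 2 `CC1=NC(C)=C(C(=O)O)C(c2ccsc2)/C1=C(\O)OC/C=C/c1ccccc1` gives 44 nM in a functional assay on thoracic aorta for inhibition of Voltage-gated L-type calcium channel (Rattus norvegicus) (on this read-out higher numbers stand for weaker inhibition and lower numbers for stronger inhibition), the higher of the two numbers recorded so far. Compound 1 `CC1=NC(C)=C(C(=O)O)C(c2cccc(F)c2)/C1=C(\O)OC/C=C/c1ccccc1` gives 20 nM, and the step of a 2.2-fold higher number from compound 1 to compound 2 (0.34 log units; beyond the scatter) came with thiophen-3-yl in place of 3-fluorophenyl. Compound 3 `CC1=NC(C)=C(C(=O)O)C(c2ccoc2)/C1=C(\O)OC/C=C/c1ccccc1` carries the change (furan-3-yl in place of thiophen-3-yl on a saturated ring carbon). Among the measured compounds shown here, no measured step swaps one five-membered ring for another, so that single step is only a loose guide. The step to compound 3 is expected to be small, at a 1.4-fold higher number from compound 2 to compound 3 (0.13 log units; within the scatter). The number for compound 3 is estimated at 60 nM, within 20 nM to 180 nM.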

Compound 3, half-maximal inhibitory concentration: 130 nM
Compound 3: middle estimate off by 2.2-fold (0.34 log units), on the low side; measured number inside the range.
By their numbers in this assay, from the lowest: compound 1; then compound 2; then compound 3.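

In this assay, this position separates two five-membered aromatic rings that match in heavy atoms and in counted donors and acceptors: furan-3-yl in place of thiophen-3-yl gives a 3.0-fold higher number from compound 2 to compound 3 (0.47 log units; beyond the scatter) on the saturated ring carbon. Furan-3-yl in place of 3-fluorophenyl gives a 6.5-fold higher number from compound 1 to compound 3 (0.81 log units; beyond the scatter), the largest step among the three compounds. No measurement here explains the difference between the sulfur and oxygen rings. From the compounds shown here alone, it remains open whether pyridin-3-yl or 3-chlorophenyl at this position would fall within this range.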